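Does Losing One Double Bond Change Cytotoxicity?

The source may report more compounds than this note shows. Statements on the series, on what has been measured and on what is new or still open speak of the compounds shown alone.

In an ADME assay on RAW264.7 cells (Mus musculus) for cytotoxicity, read by MTT assay (on this read-out higher numbers stand for weaker inhibition and lower numbers for stronger inhibition), compound 1 `CC(C)CCOc1cccc(O)c1C(=O)/C=C/c1ccc(O)cc1` gives > 30000 nM, which is a limit. Compound 2 `CCCCCCCCCCOc1cccc(O)c1C(=O)/C=C/c1ccc(O)cc1` gives > 30000 nM, also a limit. Compound 3 `CCCCCCCCCCCCOc1cccc(O)c1C(=O)/C=C/c1ccc(O)cc1` gives > 30000 nM, again a limit. Compound 4 `CCCCCCCCCCCCOc1cccc(O)c1C(=O)CCc1ccc(O)cc1` differs from compound 3 at one place: 2-(4-hydroxyphenyl)ethyl in place of 2-(4-hydroxyphenyl)ethenyl on a carbonyl carbon. The nearest measured steps are a step that the two limits leave unreadable from compound 1 to compound 2, a step that the two limits leave unreadable from compound 1 to compound 3 and a step that the two limits leave unreadable from compound 2 to compound 3. They alter a saturated chain rather than this group on the carbonyl carbon, so they bear on the change only loosely. Because the limit of > 30000 nM in this assay, at which 3 of the 3 values shown sit, no step size can be carried over. The expected change, a step that the limit leaves unreadable from compound 3 to compound 4, is none beyond the scatter, with no direction foreseen. Compound 4 is estimated at 35000 nM, within an expected range of 15000 nM to 80000 nM.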

Compound 4, half-maximal inhibitory concentration: > 30000 nM
Compound 4: a limit, no number (the forecaster's own chance of this, stated with the estimate: 75%); the middle value is on the limit's open side.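

Within the data shown here, compound 3 and compound 4 both give only a limit, so no step between them can be read. Whether 2-(4-hydroxyphenyl)ethyl in place of 2-(4-hydroxyphenyl)ethenyl changes cytotoxicity at all stays open, with every compound resting on one limit: the limit of > 30000 nM in this assay, at which 4 of the 4 values shown sit.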